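A few compounds are considered here, and "the series" means these few. Any claim that something is new, unique, unknown or untested is made for them only; others in the source may bear on it.

Measured compounds in a functional assay on LNCaP cells (Homo sapiens) for antiproliferative activity; on this read-out lower numbers stand for stronger inhibition and higher numbers for weaker inhibition:
compound 1 `CC(=O)OCC[C@@H]1C[C@@H](c2ccc(F)c(F)c2)[C@H](NC(=O)c2cc(-c3c(Cl)cnn3C)c(Cl)o2)CN1`, compound 1 gives "not determined" (no result reported);
compound 2 `Cn1ncc(Cl)c1-c1cc(C(=O)N[C@@H]2CN[C@H](CCN3CCCC3)C[C@H]2c2ccc(Cl)c(Cl)c2)oc1Cl`, compound 2 gives 1920 nM;
compound 3 `CNC(=O)C[C@@H]1C[C@@H](c2ccc(F)c(F)c2)[C@H](NC(=O)c2cc(-c3c(Cl)cnn3C)c(Cl)o2)CN1`, compound 3 gives 50 nM.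

Among the measured compounds shown here, only two numbers are on hand. Compound 3 has the lower of them; the nearest, compound 2, sits a long way higher, beyond the scatter, and compound 1 carries no result. For the measured compounds named here, compound 2 differs from compound 3 in more than one place, so the two values show only that compound 3 is the more potent of the pair, without saying which change is responsible.

Compound 4 `CNC(=O)C[C@@H]1C[C@@H](c2ccc(Cl)c(Cl)c2)[C@H](NC(=O)c2cc(-c3c(Cl)cnn3C)c(Cl)o2)CN1` is the next entry and is not yet measured. Its difference from compound 3 is 3,4-dichlorophenyl in place of 3,4-difluorophenyl on a saturated ring carbon. Compound 2 carries the same 3,4-dichlorophenyl, but with a different group on the ring carbon two bonds away, so no single-change comparison exists for this swap.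

Going by the values given here, with no measured step for the halogen exchange, the expectation for compound 4 is a step of a 1.2-fold higher number from compound 3 to compound 4 (0.08 log units; within the scatter) of modest size, in either direction, not clearly beyond the scatter. Compound 4 is accordingly estimated at 60 nM, with a range from 20 nM to 200 nM in this assay.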

Compound 4, half-maximal inhibitory concentration: 40 nM
The estimate for compound 4 lay 1.5-fold (0.18 log units) above the measured number; the measured number falls inside the stated range.
By their numbers in this assay, from the lowest: compounds 4 and 3 (each within the scatter of the next); then compound 2.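

In this assay, 3,4-dichlorophenyl in place of 3,4-difluorophenyl on the saturated ring carbon gives a 1.3-fold lower number from compound 3 to compound 4 (0.10 log units; within the scatter), so in this pair the position holds either halogen pair with no change beyond the scatter. With 3,4-dichlorophenyl held constant, methylcarbamoyl in place of (pyrrolidin-1-yl)methyl on the saturated chain carbon gives a 48-fold lower number from compound 2 to compound 4 (1.68 log units; beyond the scatter), a large step that now isolates the chain group as a change with a clear effect on the read-out, which the earlier two-place comparison could not do. No measured data on these compounds explain the size of either step.

Among the compounds shown here, only two halogen pairs on the phenyl are compared here, so the outcome with an unsubstituted phenyl, a single chlorine or a methoxy group at this position remains open. On the chain, the compounds shown leave open how a primary amide, a carboxylic acid, a simple primary amine or a longer chain ending in methylcarbamoyl would compare with the methylcarbamoyl group of compound 4.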